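This account rests on a few compounds, and the source may have more. Where it says the series, first, only, none or still open, it means among the compounds named here.

Measured in a functional assay on EBC-1 cells (Homo sapiens) for antiproliferative activity, with a stated time of 72 h; on this read-out higher numbers stand for weaker inhibition and lower numbers for stronger inhibition:
compound 1 `OCCn1cc(-c2cc(F)c3ncc(Cc4ccc5ncccc5c4)n3c2)cn1`: 0.34 nM
compound 2 `COc1ccc(-c2cc(F)c3ncc(Cc4ccc5ncccc5c4)n3c2)cc1F`: 407 nM

Of these two numbers, compound 2 has the higher, at 407 nM. Compound 3 `O=C(NC1CCCNC1)c1ccc(-c2cc(F)c3ncc(Cc4ccc5ncccc5c4)n3c2)cc1F` differs from compound 2 by one change: (piperidin-3-yl)carbamoyl in place of methoxy on an aromatic carbon. In words, (piperidin-3-yl)carbamoyl takes the place of methoxy. Within the data shown here, the only measured step, a 1200-fold higher number from compound 1 to compound 2 (3.08 log units; beyond the scatter), exchanged the whole aromatic substituent that this change alters in part, and it shows how far the number can move with that substituent. Among the measured compounds shown here, no measured compound carries a carbamoyl group, so the size stays uncertain. In this assay, a large move to a lower number is expected: a 12-fold lower number from compound 2 to compound 3 (1.07 log units; beyond the scatter). Compound 3 is estimated at 35 nM, with an expected range from 3 nM to 350 nM.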

Compound 3, half-maximal inhibitory concentration: 138 nM
Estimate against measurement, compound 3: 3.9-fold (0.60 log units) below; the range from low to high includes it.
By their numbers in this assay, from the lowest: compound 1; then compound 3; then compound 2.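

In this assay, the place ortho to a fluoro group on the carbon-only aromatic ring accepts the much larger (piperidin-3-yl)carbamoyl, which gives a 2.9-fold lower number from compound 2 to compound 3 (0.47 log units; beyond the scatter) and so moves the number in the opposite direction to the earlier step. Even so, compound 1 at 0.34 nM keeps the lowest number of the three. Nothing at hand gives a reason for this step.

On these data alone, it remains open whether the amide or the piperidine ring carries the change. A primary carboxamide or a carboxylic acid at this place would help separate them.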